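Methyl on the five-membered ring nitrogen and aryl swap

The compounds below may be only part of what the source reports. "The series", "measured", "known", "first", "only" and "open" are said of these compounds alone.

In a functional assay on A549 cells (Homo sapiens) for antiproliferative activity, read by MTT assay, with a stated time of 72 h (a higher number here means a weaker inhibitor, a lower number a stronger inhibitor), compound 1 `COc1ccc(-n2c(=O)c(C(=O)Nc3ccc(Oc4ccnc5[nH]ccc45)cc3)cc3cccnc32)cc1` gives 930 nM and compound 2 `O=C(Nc1ccc(Oc2ccnc3[nH]ccc23)cc1)c1cc2cccnc2n(-c2ccc(F)c(Cl)c2)c1=O` gives 680 nM. Compound 3 `COc1ccc(-n2c(=O)c(C(=O)Nc3ccc(Oc4ccnc5c4ccn5C)cc3)cc3cccnc32)cc1` gives 3460 nM in this assay. The two cores differ by methyl in place of hydrogen on an aromatic nitrogen, and the step of a 3.7-fold higher number from compound 1 to compound 3 (0.57 log units; beyond the scatter) is the only one beyond the scatter here. The change 3-chloro-4-fluorophenyl in place of 4-methoxyphenyl on an aromatic nitrogen made the step of a 1.4-fold lower number from compound 1 to compound 2 (0.14 log units; within the scatter). Compound 4 `Cn1ccc2c(Oc3ccc(NC(=O)c4cc5cccnc5n(-c5ccc(F)c(Cl)c5)c4=O)cc3)ccnc21` carries the same change on the core of compound 3, (3-chloro-4-fluorophenyl in place of 4-methoxyphenyl on an aromatic nitrogen), with the place described in the same words. The step from compound 3 to compound 4 is expected to be about a 1.4-fold lower number from compound 3 to compound 4 (0.14 log units; within the scatter), resting on compound 1 to compound 2 a 1.4-fold lower number from compound 1 to compound 2 (0.14 log units; within the scatter). In this assay compound 4 is therefore estimated at 2500 nM, with an expected range from 1200 nM to 5500 nM.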

Compound 4, half-maximal inhibitory concentration: 820 nM
Compound 4: the middle estimate sits 3.0-fold (0.48 log units) above what was measured; the measured number lies below the stated range.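

In this assay, the swap to 3-chloro-4-fluorophenyl from 4-methoxyphenyl does not carry between cores at one size, since a 4.2-fold lower number from compound 3 to compound 4 (0.63 log units; beyond the scatter) differs from the step on the core of compound 1: the same change on two cores in this assay, a 1.4-fold lower number (0.14 log units; within the scatter) from compound 1 to compound 2 and a 4.2-fold lower number (0.63 log units; beyond the scatter) from compound 3 to compound 4, 3.1-fold (0.49 log units) apart, beyond the scatter of two such steps. The methyl change, seen on the other side of the same four compounds as a 1.2-fold higher number from compound 2 to compound 4 (0.08 log units; within the scatter), also depends on the aryl group present: the same change on two cores in this assay, a 3.7-fold higher number (0.57 log units; beyond the scatter) from compound 1 to compound 3 and a 1.2-fold higher number (0.08 log units; within the scatter) from compound 2 to compound 4, 3.1-fold (0.49 log units) apart, beyond the scatter of two such steps. The two changes are therefore not additive in these compounds, but this shows neither why nor whether the same holds for any other aryl group.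

Open, going by these compounds, is how an ethyl group or a longer chain would read in place of that methyl. Also open, on these data alone, is how an aryl group bearing an amine or a carboxylic acid would behave on either core.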